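The source may hold more compounds than are shown below. What is called first, only, known or untested is meant among the compounds shown, and "the series" means these compounds.

Compound 2 `Cc1ccc(C(=O)Oc2ccc(O)c(C(C)(C)C)c2)cc1` is an ester built on the shared core. In an assay on isolated protein for antagonist activity at Bile acid receptor (Homo sapiens), read by HTRF, with a stated time of 30 min (a higher number here means a weaker inhibitor, a lower number a stronger inhibitor), compound 2 gives > 100000 nM, which is a limit of the assay rather than a measured number. Going by the values given here, compound 1 `CC(C)(C)c1cc(OC(=O)/C=C/c2ccccc2)ccc1O` is the only other compound in view. In this assay compound 1 gives > 100000 nM, again a limit and not a number. Both values share (the limit of > 100000 nM in this assay, at which 2 of the 2 values shown sit). Compound 3 `Cc1ccccc1C(=O)Oc1ccc(O)c(C(C)(C)C)c1` carries 2-methylphenyl in place of 4-methylphenyl on a carbonyl carbon. Among the compounds with values here, no measured step shows what this change does. The expected step of a number no higher from compound 2 to compound 3 (the limit leaves the size open) is none beyond the scatter. Compound 3 is expected to give 100000 nM, within a range from 30000 nM to 300000 nM, most likely reported again only as a limit.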

Compound 3, half-maximal inhibitory concentration: > 100000 nM
Compound 3: only a limit was reported (the forecaster's own chance of this, stated with the estimate: 85%); the middle value sits exactly at the limit.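

Going by these compounds alone, the results for compound 2 and compound 3 are both limits in this assay, and no step between them can be read. Still open, as far as these compounds go, is whether 2-methylphenyl and 4-methylphenyl differ in strength of inhibition at all.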